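Bromo in place of methoxy on two related cores

This account rests on a few compounds, and the source may have more. Where it says the series, first, only, none or still open, it means among the compounds named here.

Compound 1 `COC1=NOC2(CCCN(C)C2)C1`: in an assay on cell membranes for displacement of a labelled ligand from Neuronal acetylcholine receptor; alpha4/beta2 (Rattus norvegicus) (on this read-out lower numbers stand for stronger inhibition and higher numbers for weaker inhibition), compound 1 gives > 100000 nM, a limit of the assay.
Compound 2 `BrC1=NOC2(C1)CN1CCC2C1`: in this assay compound 2 gives 5000 nM.
Compound 3 `COC1=NOC2(C1)CN1CCC2C1`: in this assay compound 3 gives 16000 nM.

Compound 4 `CN1CCCC2(CC(Br)=NO2)C1` is not yet measured. The difference between the core of compound 1 and the core of compound 3 is not broken down here. Between the measured pair the change is bromo in place of methoxy on a carbon with a double bond to nitrogen, and it gives a 3.2-fold lower number from compound 3 to compound 2 (0.51 log units; beyond the scatter). Compound 4 arises from compound 1 by the same kind of change, (bromo in place of methoxy on a carbon with a double bond to nitrogen); the surroundings differ in that the place lies in a system of two rings rather than a system of three rings. Compound 1 stands at the limit of > 100000 nM in this assay, at which 1 of the 3 values shown sits, so the start is known only as a limit. Because of a 3.2-fold lower number from compound 3 to compound 2 (0.51 log units; beyond the scatter), the expected step is an at least 1.6-fold lower number from compound 1 to compound 4 (0.22 log units; that floor lies within the scatter) in this assay. Compound 4 is expected near 60000 nM, within 15000 nM to 300000 nM, with a fair chance that only a limit is again reported.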

Compound 4, inhibition constant: 44000 nM
For compound 4 the middle estimate is 1.4-fold (0.13 log units) above the measured one, and the stated range covers the measured number.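

In this assay, bromo in place of methoxy gives an at least 2.2-fold lower number from compound 1 to compound 4 (0.35 log units; beyond the scatter), so the change keeps its direction on the second core. Compound 1 gives > 100000 nM, a limit of the assay and not a number, so this step has a floor but no known size. The direction carries across these two cores, but whether the size carries remains unsettled: the same change on two cores in this assay, a 3.2-fold lower number (0.51 log units; beyond the scatter) from compound 3 to compound 2 and an at least 2.2-fold lower number (0.35 log units; beyond the scatter) from compound 1 to compound 4; the limit leaves it open whether they differ

Open, from the compounds shown here alone, is what chloro, an amine or an ethoxy group would give on the same carbon with a double bond to nitrogen, on either core. Also open, going by these compounds, is whether any of these would give a lower number than bromo in this assay.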